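Cytotoxicity notes on amide variation at the shared core

The compounds below may be only part of what the source reports. "The series", "measured", "known", "first", "only" and "open" are said of these compounds alone.

Compound 3 `O=C(Nc1ccc2nc(NC(=O)C3CCCCC3)sc2c1)c1ccc(Cl)cc1Cl` belongs to a small set built on the shared core of compound 1 `O=C(Nc1ccc2nc(NC(=O)C3CCCCC3)sc2c1)c1cccc(Oc2ccccc2)c1` and compound 2 `N#Cc1ccc(C(=O)Nc2ccc3nc(NC(=O)C4CCCCC4)sc3c2)cc1`. In a functional assay on WI-38 VA13 cells (Homo sapiens) for cytotoxicity (on this read-out lower numbers stand for an effect already at smaller amounts and higher numbers for an effect only at larger amounts of compound), compound 3 gives only a limit, > 4 ug/mL. Compound 1 likewise gives only a limit, > 4 ug/mL. Compound 2 gives 3.3 ug/mL. Among the measured compounds shown here, the one measured step on this carbonyl, an at least 1.2-fold higher number from compound 2 to compound 3 (0.08 log units; that floor lies within the scatter), has a floor within the scatter, and its end sits at the limit of > 4 ug/mL in this assay, at which 2 of the 3 values shown sit. Compound 4 `Cc1coc(C)c1C(=O)Nc1ccc2nc(NC(=O)C3CCCCC3)sc2c1` carries the change (2,4-dimethylfuran-3-yl in place of 2,4-dichlorophenyl on a carbonyl carbon). For the measured compounds named here, no measured step involves a five-membered aromatic ring, so this change is read like the step to compound 3 and is expected to give no step beyond the scatter, a step that the limit leaves unreadable from compound 3 to compound 4. Compound 4 is therefore estimated at 4.5 ug/mL, between 2.5 ug/mL and 8 ug/mL, most probably again reported only as a limit.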

Compound 4, half-maximal effective concentration: 2.7 ug/mL
Beside the measured number, compound 4's estimate is 1.7-fold (0.22 log units) above it; low and high end bracket the measured number.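

In this assay, 2,4-dimethylfuran-3-yl puts the first five-membered aromatic ring on this carbonyl carbon, and the result is a measured number rather than a limit. The change from 4-cyanophenyl gives a 1.2-fold lower number from compound 2 to compound 4 (0.09 log units; within the scatter), so these two groups are not separated on this read-out. The change from 2,4-dichlorophenyl gives an at least 1.4-fold lower number from compound 3 to compound 4 (0.17 log units; that floor lies within the scatter), and its true size stays unreadable because one end is a limit: the limit of > 4 ug/mL in this assay, at which 2 of the 4 values shown sit.

Still open, going by these compounds, is whether an amine or a carboxylic acid in place of these aromatic groups on the carbonyl carbon would shift the number beyond the scatter.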